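A Hydroxy Swap on the Sulfonamide Chain

This account rests on a few compounds, and the source may have more. Where it says the series, first, only, none or still open, it means among the compounds named here.

Compound 1, `CCCNS(=O)(=O)c1ccc(Nc2ncc3c(n2)N(C2CCCC2)[C@H](CC)C(=O)N3C)cc1`, is the stronger of the two compounds measured here. In an assay for inhibition of serine/threonine-protein kinase PLK2 (Homo sapiens), read by FRET and Z'-LYTE, with a stated time of 1 h (a lower number here means a stronger inhibitor, a higher number a weaker inhibitor), compound 1 gives 17.8 nM, the lowest of the two numbers available. Within the data shown here, the only comparison is compound 2, `CCC1C(=O)N(C)c2cnc(-n3ccc4cc(C(N)=O)ccc43)nc2N1c1ccn(C)n1`, which is built on a different arrangement and in this assay gives 384 nM; the gap between the two values lies beyond the scatter of repeated measurements, but since the two differ in several places at once, the numbers alone cannot be tied to any single change.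

Compound 3, `CC[C@@H]1C(=O)N(C)c2cnc(Nc3ccc(S(=O)(=O)NCCO)cc3)nc2N1C1CCCC1`, has not been measured. It differs from compound 1 in one place: hydroxy in place of methyl on a saturated chain carbon, two bonds along the chain from a sulfonamide nitrogen. Among the measured compounds shown here, no measured pair isolates this change, so the expectation rests on compound 1 alone. The step of a 1.4-fold higher number from compound 1 to compound 3 (0.15 log units; within the scatter) is expected to be small, likely within the scatter or at most a slight weakening. Compound 3 is therefore estimated at about 25 nM, with a range from 10 nM to 63 nM.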

Compound 3, half-maximal inhibitory concentration: 7.86 nM
Estimate against measurement, compound 3: 3.2-fold (0.50 log units) above; measured number outside the range, below it.
By their numbers in this assay, from the lowest: compound 3; then compound 1; then compound 2.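

The sulfonamide chain of compound 1 tolerates a change at this place: in this assay the swap of hydroxy in place of methyl, on a saturated chain carbon, two bonds along the chain from a sulfonamide nitrogen, gives a 2.3-fold lower number from compound 1 to compound 3 (0.35 log units; beyond the scatter) and so brings a modest gain rather than a loss. Among these compounds, this is the first pair here that differs in one place, so unlike the gap between compound 1 and compound 2, this step can be tied to a single change, propyl to 2-hydroxyethyl, in which the entering hydroxy counts as a hydrogen-bond donor and acceptor and the leaving methyl as neither. Nothing available explains why the number falls, and the step stands without a known cause.

Going by these compounds, whether the gain belongs to the hydroxy itself remains open, as does whether an amine, a carboxylic acid or a methoxy group at the same place would give a similar number. On these data alone, it is equally open whether a longer chain carrying the hydroxy would keep the gain, and one pair sets no pattern beyond compound 1 and compound 3.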